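Trading Cyclopentyloxy for 4-Fluorophenyl

The compounds below may be only part of what the source reports. "The series", "measured", "known", "first", "only" and "open" are said of these compounds alone.

In a physicochemical assay for solubility, read by HPLC, in phosphate buffer, with a stated time of 20 h, at pH 7.4 (on this read-out higher numbers stand for higher solubility and lower numbers for lower solubility), compound 1 `O=C(O)C[C@H]1CC[C@H](c2ccc(C(=O)Nc3nnc(COC4CCCC4)s3)cc2)CC1` gives 9000 nM as the lower of the two actual numbers at hand. Compound 2 `O=C(Nc1nnc(NC2CCCC2)s1)c1ccc(O[C@H]2CC[C@@H](C(=O)O)CC2)cc1` gives 26000 nM on the same scale. Compound 3 `O=C(Nc1nnc(Nc2ccccc2)s1)c1ccc(O[C@H]2CC[C@@H](C(=O)O)CC2)cc1` stands at < 2000 nM as a limit of the assay and not a number.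

Compound 4 `O=C(O)C[C@H]1CC[C@H](c2ccc(C(=O)Nc3nnc(Cc4ccc(F)cc4)s3)cc2)CC1` has not yet been measured. It differs from compound 1 by 4-fluorophenyl in place of cyclopentyloxy on a saturated chain carbon bound to an aromatic carbon with 4-fluorophenyl in place of cyclopentyloxy on a saturated chain carbon bound to an aromatic carbon. Going by the values given here, the one measured step that bears on this change is an at least 13-fold lower number from compound 2 to compound 3 (1.11 log units; beyond the scatter) and it is large. That step also puts an aromatic ring in place of a non-aromatic one, though at a different place. On the strength of an at least 13-fold lower number from compound 2 to compound 3 (1.11 log units; beyond the scatter) a lower number is expected for compound 4 in this assay by a moderate step beyond the scatter. The expected change is a 3.6-fold lower number from compound 1 to compound 4 (0.56 log units; beyond the scatter) on this estimate. For compound 4 the estimate is 2500 nM with an expected range from 800 nM to 8000 nM in this assay.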

Compound 4, solubility: < 2000 nM
Compound 4 ended at the assay's limit; the forecaster's own chance of this, stated with the estimate: 45%; at least 1.2-fold (0.09 log units) between middle value and limit.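

In this assay the change to 4-fluorophenyl in place of cyclopentyloxy on a saturated chain carbon bound to an aromatic carbon gives an at least 4.5-fold lower number from compound 1 to compound 4 (0.65 log units; beyond the scatter) and is the first step shown at this place. Compound 4 stands at < 2000 nM as a limit of the assay and not a number, so this step has only a lower bound. The earlier step of an at least 13-fold lower number from compound 2 to compound 3 (1.11 log units; beyond the scatter) put phenyl in place of cyclopentyl on a nitrogen on an aromatic ring, and an aromatic ring entering now goes with a lower number at a second place too, though the two step sizes cannot be ranked: the limit of < 2000 nM in this assay, at which 2 of the 4 values shown sit.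

On these data alone, how far compound 4 lies past the limit remains open. So does whether a plain benzyl or a morpholinomethyl group at this place would stay above the limit.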